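Swapping a sulfonyl arm for a fluorophenyl urea

The source may report more compounds than this note shows. Statements on the series, on what has been measured and on what is new or still open speak of the compounds shown alone.

Of the compounds shown here, two of one family have been tested in a functional assay on MDA-MB-231 cells (Homo sapiens) for antiproliferative activity, read by MTT assay, with a stated time of 48 h; on this read-out lower numbers stand for stronger inhibition and higher numbers for weaker inhibition. Compound 1, `C=CS(=O)(=O)N1CCN(c2nc(OC[C@H]3CCCN3C)nc3sc(-c4ccc(C#N)cc4)cc23)CC1`, gives 3010 nM. Compound 2, `CN1CCN(c2ccc(-c3cc4c(N5CCN(S(=O)(=O)/C=C/c6ccccc6)CC5)ncnc4s3)cc2)CC1`, gives 5900 nM. Although the number for compound 2 is the upper one of the two, the gap between compound 1 and compound 2 lies within the usual scatter of such a measurement, so neither can be called the more potent.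

Compound 3, `CN1CCN(c2ccc(-c3cc4c(N5CCN(C(=O)Nc6ccccc6F)CC5)ncnc4s3)cc2)CC1`, is the next step from compound 2. The change is: (2-fluorophenyl)carbamoyl in place of (2-phenylethenyl)sulfonyl on an amine nitrogen in a ring. Among the measured compounds shown here, no comparable exchange has been measured here, so there is no reference step to lean on. The expectation is that the step of a 1.4-fold higher number from compound 2 to compound 3 (0.13 log units; within the scatter) will be modest, somewhat toward a weaker read-out, but close to the edge of the scatter. Compound 3 is thus expected to give about 8000 nM, with a plausible range from 2500 nM to 25000 nM.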

Compound 3, half-maximal inhibitory concentration: 10300 nM
Beside the measured number, compound 3's estimate is 1.3-fold (0.11 log units) below it; the range from low to high includes it.
By their numbers in this assay, from the lowest: compounds 1, 2 and 3 (each within the scatter of the next, the first and the last beyond it).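

In this assay, putting (2-fluorophenyl)carbamoyl in place of (2-phenylethenyl)sulfonyl on the amine nitrogen in the ring gives a 1.7-fold higher number from compound 2 to compound 3 (0.24 log units; within the scatter), so the two arms cannot be told apart on this read-out. Among the compounds shown here, this is the first sign that this nitrogen can carry a carbonyl-linked arm with one hydrogen-bond donor, as well as a sulfonyl arm with none, without a step beyond the scatter. No supporting data are available to explain this result.

For the compounds shown here, the single step changes the linking group, the alkene and the fluorine together, leaving the contribution of each part unresolved. A phenylcarbamoyl arm without fluorine would separate the fluorine from the linker, while a small acetyl group would test whether this position needs an aromatic ring at all.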